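A Methoxy Variant Within a Weakly Cytotoxic Series

The compounds below may be only part of what the source reports. "The series", "measured", "known", "first", "only" and "open" are said of these compounds alone.

Compound 1 `Cc1c(-c2csc(/N=C3\S/C(=C\c4ccccc4)C(=O)N3c3ccccc3)n2)c(=O)n(-c2ccccc2)n1C` is the simplest member of this set. In a functional assay on HepG2 cells (Homo sapiens) for cytotoxicity, read by sulforhodamine B assay, with a stated time of 72 h (a lower number here means a stronger inhibitor, a higher number a weaker inhibitor), compound 1 gives 63400 nM. Compound 2 `Cc1c(-c2csc(/N=C3\S/C(=C\c4ccc(Cl)cc4)C(=O)N3c3ccccc3)n2)c(=O)n(-c2ccccc2)n1C` carries chloro in place of hydrogen on an aromatic carbon. For compound 2 the assay reports only a limit, > 100000 nM. Compound 3 `Cc1c(-c2csc(/N=C3\S/C(=C\c4ccc(N(C)C)cc4)C(=O)N3c3ccccc3)n2)c(=O)n(-c2ccccc2)n1C` carries dimethylamino on an aromatic carbon instead. For compound 3 the assay likewise reports only a limit, > 100000 nM, so compound 3 stands at the weak end of what can be read, with no number of its own.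

Compound 4 `COc1ccc(/C=C2\S/C(=N\c3nc(-c4c(C)n(C)n(-c5ccccc5)c4=O)cs3)N(c3ccccc3)C2=O)cc1` differs from compound 3 by methoxy in place of dimethylamino on an aromatic carbon. Among the measured compounds shown here, the steps that bear on this are an at least 1.5-fold higher number from compound 1 to compound 2 (0.19 log units; that floor lies within the scatter) and an at least 1.5-fold higher number from compound 1 to compound 3 (0.19 log units; that floor lies within the scatter), while a step that the two limits leave unreadable from compound 2 to compound 3. Both substituted analogues reached (the limit of > 100000 nM in this assay, at which 2 of the 3 values shown sit), and the swap to methoxy is not expected to move far from that: compound 4 is estimated at 100000 nM, within 40000 nM to 300000 nM, and the expected step is a number no higher from compound 3 to compound 4 (the limit leaves the size open).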

Compound 4, half-maximal inhibitory concentration: 13200 nM
Beside the measured number, compound 4's estimate is 7.6-fold (0.88 log units) above it; the whole stated range lies above it.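

On this aromatic carbon, the 4-methoxyphenyl group gives a 4.8-fold lower number from compound 1 to compound 4 (0.68 log units; beyond the scatter), so a substituent here need not weaken the compound, as the chloro and dimethylamino analogues had suggested. Methoxy also separates clearly from both those groups, with an at least 7.5-fold lower number from compound 3 to compound 4 (0.87 log units; beyond the scatter) and an at least 7.5-fold lower number from compound 2 to compound 4 (0.87 log units; beyond the scatter). In this assay, the outcome therefore depends on which group sits here, not merely on whether one does.

Going by these compounds, whether a hydroxy or ethoxy group on this carbon would match methoxy stays open. The values of compound 2 and compound 3 are both limits, so the step between them cannot be read.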